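The compounds below may be only part of what the source reports. "The series", "measured", "known", "first", "only" and "open" are said of these compounds alone.

Working notes on the series

Three compounds of this set have been run in a functional assay on cells (Lymphocyte, Homo sapiens), read by a luciferase reporter and ATP content, with a stated time of 48 h, tested at 5 uM; on this read-out lower numbers stand for a stronger effect and higher numbers for a weaker effect at the one concentration tested. Compound 3, `Cc1nc(OC2CCC2)nc(OC2CCC2)c1O`, gives 99%. Compound 1, `Cc1nc(N2CCC2)nc(OC2CCC2)c1O`, gives 98%. Compound 2, `CCCCCCCCCCCCCCc1nc(OC2CCC2)nc(N2CCC2)c1O`, gives 105%. All three numbers sit within the scatter of one another, so no order among them can be read from this assay.

One change has been measured directly. From compound 3 to compound 1 the change is azetidin-1-yl in place of cyclobutyloxy on an aromatic carbon, and it moved the read-out by a number 1 percentage points lower from compound 3 to compound 1 (within the scatter). The same kind of change is now applied to compound 2 to give compound 4, `CCCCCCCCCCCCCCc1nc(N2CCC2)nc(N2CCC2)c1O`: the change is azetidin-1-yl in place of cyclobutyloxy on an aromatic carbon. The two surroundings are not identical in wording: in compound 3 the carbon carrying the change is meta to a cyclobutyloxy group (5 heavy atoms) and meta to a methyl group (1 heavy atom), whereas in compound 2 it is meta to a large group and meta to an azetidin-1-yl group (4 heavy atoms). The difference between the cores of compound 2 and compound 3 is not broken down here.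

Given that the measured step from compound 3 to compound 1 stayed within the scatter, the expectation for compound 4 in this assay is a step of a number 2 percentage points lower from compound 2 to compound 4 (within the scatter), likewise within the scatter. Compound 4 is accordingly estimated at 103%, with a range from 90% to 115%.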

Compound 4, a percentage reported as activity, at one concentration (the size of the read-out at that concentration, not a potency): 46%
Compound 4: the middle estimate sits 57 percentage points above what was measured; measured number outside the range, below it.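

In this assay, azetidin-1-yl in place of cyclobutyloxy on the aromatic carbon between two ring nitrogen atoms gives a number 59 percentage points lower from compound 2 to compound 4 (beyond the scatter), so on this core the change is linked to a large drop in the read-out at the one concentration tested. The size of the step does not carry from one core to the other, and a step seen on one core is therefore a poor guide to the step on the other: the same change on two cores in this assay, a number 1 percentage points lower (within the scatter) from compound 3 to compound 1 and a number 59 percentage points lower (beyond the scatter) from compound 2 to compound 4, 58 percentage points apart, beyond the scatter of two such steps This rests on a single pair of steps and shows neither which difference between the cores sets the size of the step nor why it does so, since the cores of compound 2 and compound 3 differ in both the large group and the azetidin-1-yl or cyclobutyloxy group on the other ring carbon, and these differences are not separated here.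

Open, going by these compounds, is whether a hexyl or decyl chain in place of the large group would keep the drop seen with compound 4, which would show how much of the core difference lies in the chain. Also open, on these data alone, is whether another amine, such as pyrrolidin-1-yl or dimethylamino, would behave as azetidin-1-yl does at the same ring carbon.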